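Swapping pyridin-4-yl for pyrazin-2-yl on compound 3

The source may hold more compounds than are shown below. What is called first, only, known or untested is meant among the compounds shown, and "the series" means these compounds.

Measured in a functional assay for inhibition, with Homo sapiens as the target; on this read-out lower numbers stand for stronger inhibition and higher numbers for weaker inhibition:
- compound 1 `Cc1nc2ccc(COc3ccc4c(c3)c(SC(C)(C)C)c(CC(C)(C)C(=O)O)n4Cc3ccc(Cl)cc3)cc2s1`: 6 nM
- compound 2 `CC(C)(C)Sc1c(CC(C)(C)C(=O)O)n(Cc2ccc(Cl)cc2)c2ccc(OCc3nc4ccccc4o3)cc12`: < 7 nM, a limit and not a number
- compound 3 `CC(C)(C)Sc1c(CC(C)(C)C(=O)O)n(Cc2ccc(Cl)cc2)c2ccc(OCc3ccncc3)cc12`: 6 nM

Compound 3 gives 6 nM, level with compound 1 at the digits shown. Compound 2 gives only a limit, < 7 nM. That limit hides the size of two steps: a step that the limit leaves unreadable from compound 1 to compound 2 and a step that the limit leaves unreadable from compound 2 to compound 3.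

The next compound is compound 4 `CC(C)(C)Sc1c(CC(C)(C)C(=O)O)n(Cc2ccc(Cl)cc2)c2ccc(OCc3cnccn3)cc12`. It carries pyrazin-2-yl in place of pyridin-4-yl on a saturated chain carbon bound to an oxygen on an aromatic ring.

For the measured compounds named here, only one measured step at this place can be read, and it exchanged 2-methyl-1,3-benzothiazol-6-yl for pyridin-4-yl: no change at the digits printed from compound 1 to compound 3 (within the scatter). On that single step, no shift beyond the scatter is expected in this assay. Going by the values given here, no measured compound carries pyrazin-2-yl, so the range stays wide. The expected change is a 1.2-fold higher number from compound 3 to compound 4 (0.07 log units; within the scatter). For compound 4 the estimated value is 7 nM, with an expected range of 3 nM to 22 nM.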

Compound 4, half-maximal inhibitory concentration: 4 nM
The estimate for compound 4 lay 1.8-fold (0.24 log units) above the measured number; the measured number falls inside the stated range.
By their numbers in this assay, from the lowest: compounds 4, 1 and 3 (each within the scatter of the next).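

In this assay, putting pyrazin-2-yl, a six-membered aromatic ring with 2 hetero atoms, where pyridin-4-yl stood leaves the read-out within the scatter: a 1.5-fold lower number from compound 3 to compound 4 (0.18 log units; within the scatter). The comparison with the 2-methyl-1,3-benzothiazol-6-yl group of compound 1 reads the same way: a 1.5-fold lower number from compound 1 to compound 4 (0.18 log units; within the scatter). Three different aromatic groups on this saturated chain carbon now give numbers within the scatter of each other, while compound 2 gives a limit and not a number, so the steps to it cannot be read: the limit of < 7 nM in this assay, at which 1 of the 4 values shown sits.

All the groups shown at this place are aromatic rings, so it remains open whether a saturated ring such as cyclohexyl or morpholine would give a similar number. Also open, from the compounds shown here alone, is how a plain phenyl ring or an open-chain amine would read here.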